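This account rests on a few compounds, and the source may have more. Where it says the series, first, only, none or still open, it means among the compounds named here.

Three amides sharing one core have been measured in a functional assay on MGC-803 cells (Homo sapiens) for inhibition, read by MTT assay, with a stated time of 48 h; a higher number here means a weaker inhibitor, a lower number a stronger inhibitor. Compound 1 `CCCCC(=O)N(Cc1ccc(OC)c(O)c1)c1cc(OC)c(OC)c(OC)c1`, with butyl on the carbonyl carbon, gives 66 nM. Compound 2 `COc1ccc(CN(C(=O)C=C(C)C)c2cc(OC)c(OC)c(OC)c2)cc1O`, with 2-methylprop-1-en-1-yl there, gives 320 nM, and compound 3 `C#CC(=O)N(Cc1ccc(OC)c(O)c1)c1cc(OC)c(OC)c(OC)c1`, with ethynyl, gives 170 nM. Compound 3 cannot be told apart from compound 2, but it is weaker than compound 1. The two steps read a 1.9-fold lower number from compound 2 to compound 3 (0.27 log units; within the scatter) and a 2.6-fold higher number from compound 1 to compound 3 (0.41 log units; beyond the scatter).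

Among the compounds with values here, compound 4 `CCC/C=C/C(=O)N(Cc1ccc(OC)c(O)c1)c1cc(OC)c(OC)c(OC)c1` keeps the core and changes only this group: pent-1-en-1-yl in place of ethynyl on a carbonyl carbon. Within the data shown here, no measured compound carries pent-1-en-1-yl, so the evidence is indirect. This group has a double bond like the group in compound 2, and a longer carbon chain like the butyl of compound 1. The closest guide is a 4.8-fold higher number from compound 1 to compound 2 (0.69 log units; beyond the scatter), a modest step, and the other measured steps are no larger. These groups span only a narrow range, so a small shift toward a lower number is expected, not one beyond the scatter. The estimated step is a 1.4-fold lower number from compound 3 to compound 4 (0.15 log units; within the scatter). The expected value for compound 4 is 120 nM, with an estimated range of 45 nM to 320 nM.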

Compound 4, half-maximal inhibitory concentration: 70 nM
Compound 4: the middle estimate sits 1.7-fold (0.23 log units) above what was measured, within the range that was stated.
By their numbers in this assay, from the lowest: compounds 1 and 4 (each within the scatter of the next); then compounds 3 and 2 (each within the scatter of the next).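

In this assay the step of a 1.1-fold higher number from compound 1 to compound 4 (0.03 log units; within the scatter) puts butyl and pent-1-en-1-yl within the scatter of each other on this carbonyl carbon, so a double bond in the chain does not by itself go with the weaker number of compound 2. The two groups with a double bond are now separated by a 4.6-fold lower number from compound 2 to compound 4 (0.66 log units; beyond the scatter) and pent-1-en-1-yl also departs from ethynyl with a 2.4-fold lower number from compound 3 to compound 4 (0.39 log units; beyond the scatter) so what the group holds beyond its double bond matters at this place. No measurement at hand explains these steps.

The compounds shown leave open whether a longer chain such as heptyl, a cyclohexyl group or a chain ending in an amine would keep the number at this level. They also leave open whether these steps hold in cells other than those of this assay.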